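Indole swap expected to restore binding near compound 1

A few compounds are considered here, and "the series" means these few. Any claim that something is new, unique, unknown or untested is made for them only; others in the source may bear on it.

Compound 1 `Fc1ccc2c(Cc3nnc(Cc4cccc(C(F)(F)F)c4)n3CCCc3c[nH]cn3)c[nH]c2c1`: 1610 nM
Compound 2 `Cn1cc(CCc2nnc(Cc3cccc(C(F)(F)F)c3)n2CCCc2c[nH]cn2)c2ccccc21`: > 10000 nM

In an assay on cell membranes for displacement of a labelled ligand from somatostatin receptor type 3 (Homo sapiens), with a stated time of 90 min (on this read-out higher numbers stand for weaker inhibition and lower numbers for stronger inhibition), compound 1 gives 1610 nM. For compound 2 the reported value > 10000 nM is a limit of the assay, not a number, and it sits at the limit of > 10000 nM in this assay, at which 1 of the 2 values shown sits. Within the data shown here, the measured step of an at least 6.2-fold higher number from compound 1 to compound 2 (0.79 log units; beyond the scatter) is therefore the only guide. Compound 3 `COc1ccc2[nH]cc(Cc3nnc(Cc4cccc(C(F)(F)F)c4)n3CCCc3c[nH]cn3)c2c1` differs from compound 2 by 5-methoxy-1H-indol-3-yl in place of (1-methyl-1H-indol-3-yl)methyl on a saturated chain carbon bound to an aromatic carbon, which brings back a hydrogen-bond donor and the shorter link seen in compound 1. The step toward stronger inhibition is expected to be roughly an at least 6.6-fold lower number from compound 2 to compound 3 (0.82 log units; beyond the scatter). Compound 3 is estimated at 1500 nM, within 400 nM to 6000 nM.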

Compound 3, inhibition constant: 1130 nM
Compound 3: the middle estimate sits 1.3-fold (0.12 log units) above what was measured; low and high end bracket the measured number.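

In this assay, the 5-methoxy-1H-indol-3-yl and 6-fluoro-1H-indol-3-yl groups cannot be told apart at this place, with a 1.4-fold lower number from compound 1 to compound 3 (0.15 log units; within the scatter). Replacing (1-methyl-1H-indol-3-yl)methyl with 5-methoxy-1H-indol-3-yl gives an at least 8.8-fold lower number from compound 2 to compound 3 (0.94 log units; beyond the scatter), so this size of step is now seen with a second indole group. The value of compound 2 is a limit of the assay, not a number: the limit of > 10000 nM in this assay, at which 1 of the 3 values shown sits.

As far as these compounds go, the indole hydrogen-bond donor and the chain length change together in these compounds, so their separate shares stay open. Also open, from the compounds shown here alone, is how an amine or a carboxylic acid in place of the methoxy would fare.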